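The compounds below may be only part of what the source reports. "The series", "measured", "known", "first", "only" and "open" are said of these compounds alone.

Three compounds sharing one core were measured in a functional assay on A-431 cells (Homo sapiens) for antiproliferative activity, read by MTT assay, with a stated time of 72 h; on this read-out higher numbers stand for weaker inhibition and lower numbers for stronger inhibition. Compound 1 `NS(=O)(=O)c1ccc(NC(=S)Nc2ccc3ncnc(Nc4ccc(Cl)c(C(F)(F)F)c4)c3c2)cc1` gives 18200 nM. Compound 2 `NS(=O)(=O)c1ccc(NC(=S)Nc2ccc3ncnc(Nc4ccc(C(F)(F)F)cc4)c3c2)cc1` gives 18000 nM, and compound 3 `NS(=O)(=O)c1ccc(NC(=S)Nc2ccc3ncnc(Nc4cccc(Cl)c4F)c3c2)cc1` gives 13100 nM. Compound 3 carries the lowest of the three numbers, but its separation from the others is small: a 1.4-fold lower number from compound 1 to compound 3 (0.14 log units; within the scatter) and a 1.4-fold lower number from compound 2 to compound 3 (0.14 log units; within the scatter), and likewise a 1.0-fold lower number from compound 1 to compound 2 (0.00 log units; within the scatter), all stay within the scatter. Compound 4 `Cc1ccc(Nc2ncnc3ccc(NC(=S)Nc4ccc(S(N)(=O)=O)cc4)cc23)cc1` has not yet been measured in this assay. It differs from compound 3 by one exchange: 4-methylphenyl in place of 3-chloro-2-fluorophenyl on a nitrogen on an aromatic ring. All three measured steps exchange the aromatic ring on this same nitrogen, swapping one substituted phenyl for another, and none of them moved the number beyond the scatter. A 4-methylphenyl is a new substituent at this place, so the measured steps bear on it only loosely. Still, the nearest evidence points to little movement, and compound 4 is expected to sit close to its neighbours, with a 1.2-fold higher number from compound 3 to compound 4 (0.09 log units; within the scatter). Compound 4 is estimated at 16000 nM, within a range of 7000 nM to 40000 nM.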

Compound 4, half-maximal inhibitory concentration: 40000 nM
The estimate for compound 4 lay 2.5-fold (0.40 log units) below the measured number; the measured number falls inside the stated range.
By their numbers in this assay, from the lowest: compounds 3, 2 and 1 (each within the scatter of the next); then compound 4.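

In this assay, among these compounds, the 4-methylphenyl group is the first exchange on this nitrogen to move the number beyond the scatter, with a 3.1-fold higher number from compound 3 to compound 4 (0.48 log units; beyond the scatter) and a 2.2-fold higher number from compound 1 to compound 4 (0.34 log units; beyond the scatter) as its steps from two of the earlier rings. The cleanest reading comes from methyl in place of trifluoromethyl on an aromatic carbon, a single change that gives a 2.2-fold higher number from compound 2 to compound 4 (0.35 log units; beyond the scatter) and shows that this one substituent matters even though the earlier ring exchanges did not separate compounds 1, 2 and 3. Compound 4 is also the only one of the four whose ring carries no fluorine or chlorine, but no measurement shown here explains the shift.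

As far as these compounds go, whether the shift follows from the methyl itself or from the absence of halogen stays open. An unsubstituted phenyl, a 4-methoxyphenyl or a 4-aminophenyl on the same nitrogen would bear on that question.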